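A few compounds are considered here, and "the series" means these few. Any claim that something is new, unique, unknown or untested is made for them only; others in the source may bear on it.

Compounds measured so far:
- compound 1, `Cc1ccc(S(=O)(=O)N[C@H]2CCN(CCCOc3ccc(C(=O)C4CC4)cc3)C2)cc1`, gives 380 nM in an assay on isolated protein for binding affinity to histamine H2 receptor (Homo sapiens); on this read-out lower numbers stand for stronger inhibition and higher numbers for weaker inhibition
- compound 2, `CC(=O)c1ccc(OCCCN2CC[C@H](NS(=O)(=O)c3ccc(C#N)cc3)C2)cc1`, gives 2300 nM in this assay

Of the compounds shown here, two have been measured so far. Compound 1 stands at the lower of the two numbers; compound 2 sits at a number that lies beyond the scatter above it. The two differ in more than one place, so their gap is simply what the two values show and is not broken down further.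

The step under study leads from compound 1 to compound 3, `O=C(c1ccc(OCCCN2CC[C@H](NS(=O)(=O)c3ccc(Br)cc3)C2)cc1)C1CC1`, which has not yet been measured. The change is small: bromo in place of methyl on an aromatic carbon. Going by the values given here, nothing in the measured pair speaks directly to this exchange, since no step between measured compounds that differ in one place is available. On that basis no step beyond the usual scatter is expected in either direction, and compound 3 is expected to come out close to compound 1, a 1.2-fold lower number from compound 1 to compound 3 (0.07 log units; within the scatter).

Compound 3 is therefore estimated at 320 nM, with a range from 100 nM to 1000 nM.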

Compound 3, inhibition constant: 290 nM
Beside the measured number, compound 3's estimate is 1.1-fold (0.04 log units) above it; the measured number falls inside the stated range.
By their numbers in this assay, from the lowest: compounds 3 and 1 (each within the scatter of the next); then compound 2.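

In this assay, going by these compounds alone, the first one-place step is a 1.3-fold lower number from compound 1 to compound 3 (0.12 log units; within the scatter), so 4-methylphenyl and 4-bromophenyl on the sulfonyl cannot be told apart on this read-out. The earlier pair could not show this, as its two compounds differ in more than one place; now a single change on this aromatic carbon, para to a large group, has been read directly, and methyl and bromo give values within the scatter of each other. Nothing available explains why the two groups read alike.

The compounds shown leave open whether this holds only for methyl and bromo or extends to other groups at the same place, such as a methoxy group, an amine, a carboxylic acid or plain hydrogen. They also leave the higher number of compound 2, at 2300 nM, unassigned to any one of its differences, so the nitrile at this place cannot be judged on its own from this set.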